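A few compounds are considered here, and "the series" means these few. Any claim that something is new, unique, unknown or untested is made for them only; others in the source may bear on it.

Going by the values given here, in a functional assay on NCI/ADR-RES cells (Homo sapiens) for inhibition (a higher number here means a weaker inhibitor of growth, a lower number a stronger inhibitor of growth), only three compounds have been read so far. Compound 1 (`O=S(=O)(/C=C/c1ccc(Cl)cc1)Cc1ccc(Nc2ncnc3ccccc23)cc1`) gives > 100000 nM, which is a limit of the assay and not a number. Compound 2 (`O=S(=O)(/C=C/c1ccc(C(F)(F)F)cc1F)Cc1ccc(Nc2ncnc3cc(Cl)ccc23)cc1`) gives > 100000 nM, which is again a limit. The picture is therefore thin: the limit of > 100000 nM in this assay, at which 2 of the 3 values shown sit. Among the compounds with values here, compound 3 (`COc1cc2ncnc(Nc3ccc(CS(=O)(=O)/C=C/c4ccc(Cl)cc4Cl)cc3)c2cc1OC`) gives 24000 nM, the only true number in the set, so it has no measured neighbour to be compared with.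

Compound 4 (`COc1cc2ncnc(Nc3ccc(CS(=O)(=O)/C=C/c4ccc(F)cc4)cc3)c2cc1OC`) keeps the rest of compound 3 and exchanges one group: 4-fluorophenyl in place of 2,4-dichlorophenyl on a double-bonded chain carbon bound to a double-bonded chain carbon. Thus 4-fluorophenyl stands in place of 2,4-dichlorophenyl on a double-bonded chain carbon bound to a double-bonded chain carbon.

Within the data shown here, no measured step shows what such an exchange does, so no shift beyond the scatter is expected in this assay, and the expectation rests on compound 3 at 24000 nM. The expected step, a 1.3-fold higher number from compound 3 to compound 4 (0.10 log units; within the scatter), stays within the usual scatter. For compound 4 the estimated value is 30000 nM, with an expected range from 8000 nM to 100000 nM.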

Compound 4, concentration for 50% growth inhibition: > 100000 nM
Compound 4: no number, only a limit (the forecaster's own chance of this, stated with the estimate: 25%); at least 3.3-fold (0.52 log units) between middle value and limit.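

In this assay, going by these compounds alone, placing 4-fluorophenyl in place of 2,4-dichlorophenyl on a double-bonded chain carbon bound to a double-bonded chain carbon gives an at least 4.1-fold higher number from compound 3 to compound 4 (0.61 log units; beyond the scatter), the only step in the set that can be read and one that lies beyond the scatter. Compound 4 gives > 100000 nM, which is a limit of the assay and not a number, so this step has a lower bound only. Compound 3 remains the only compound with a true number, while the others all sit at one point: the limit of > 100000 nM in this assay, at which 3 of the 4 values shown sit.

The compounds shown do not separate the effect of losing the two chlorine atoms from that of gaining the fluorine atom. With the rest of compound 3 kept, they also leave open how a plain phenyl, 4-methoxyphenyl or 4-aminophenyl group would read at this place.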